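A few compounds are considered here, and "the series" means these few. Any claim that something is new, unique, unknown or untested is made for them only; others in the source may bear on it.

In an ADME assay on MT4 cells (Homo sapiens) for cytotoxicity, read by MTT assay, with a stated time of 5 days (on this read-out higher numbers stand for lower toxicity in this test and lower numbers for higher toxicity in this test), compound 1 `O=C1N(Cc2cccc(Cl)c2)c2cccn2S(=O)(=O)N1Cc1ccccc1` gives 196000 nM. Compound 3 `N#CCN1C(=O)N(Cc2cccc(F)c2)S(=O)(=O)n2cccc21` gives 172000 nM. Repeated measurements of this kind naturally differ somewhat, and these two numbers lie within that usual scatter of each other, so compound 1 stands level with compound 3. Compound 2 `N#Cc1ccccc1CN1C(=O)N(Cc2cccc(Cl)c2)S(=O)(=O)n2cccc21` gives > 293000 nM, which is a limit of the assay and not a number.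

The next compound to consider is compound 4 `O=C1N(Cc2ccccc2Cl)c2cccn2S(=O)(=O)N1Cc1ccccc1`, which has the same atoms as compound 1, joined differently: 2-chlorophenyl in place of 3-chlorophenyl on a saturated chain carbon bound to an amide-type nitrogen in a ring. In words, 2-chlorophenyl sits in place of 3-chlorophenyl on a saturated chain carbon bound to an amide-type nitrogen in a ring.

Among the measured compounds shown here, no two measured compounds here differ in only one place, so the data offer no measured step to serve as a guide. The expectation therefore starts from compound 1 at 196000 nM, and no step beyond the scatter is expected in this assay for this change. The estimated step is a 1.0-fold lower number from compound 1 to compound 4 (0.01 log units; within the scatter). For compound 4, the expected value is 190000 nM, with an estimated range from 100000 nM to 300000 nM.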

Compound 4, half-maximal cytotoxic concentration: > 291000 nM
Compound 4: only a limit was reported (the forecaster's own chance of this, stated with the estimate: 25%); middle value at least 1.5-fold (0.18 log units) from the limit.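

Moving the chlorine, from 3-chlorophenyl to 2-chlorophenyl on a saturated chain carbon bound to an amide-type nitrogen in a ring, does not bring the number down in this assay: the step is an at least 1.4-fold higher number from compound 1 to compound 4 (0.17 log units; that floor lies within the scatter). Among the compounds shown here, this is the first direct comparison in the set, and it shows that this position tolerates the change without any sign of higher toxicity in this test. The size of the step stays uncertain, because compound 4 gives only a limit and the floor of the step lies within the usual scatter, so no real rise in the number can be claimed: the limit of > 291000 nM in this assay, at which 1 of the 4 values shown sits.

The compounds shown leave open how far the true value of compound 4 lies beyond that limit, and so whether the two chlorine placements truly differ at all. They also leave open whether an amine or a carboxylic acid in place of the chlorine, or a longer chain in place of the saturated chain carbon, would hold the number at this level in this assay.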